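Trimming the Ethyl Group on a Shared Core

The compounds below may be only part of what the source reports. "The series", "measured", "known", "first", "only" and "open" are said of these compounds alone.

Compound 1 `CCc1ccc(-c2nn3cc(-c4cccc(N)c4)nc3s2)cc1` gives 8100 nM in a functional assay on HeLa cells (Homo sapiens) for inhibition, read by cell counting, with a stated time of 4 days; a higher number here means a weaker inhibitor, a lower number a stronger inhibitor.
Compound 2 `C=C(Br)C(=O)Nc1cccc(-c2cn3nc(-c4ccc(CC)cc4)sc3n2)c1` gives 3200 nM in this assay.
Compound 3 `Nc1cccc(-c2cn3c(-c4ccccc4)csc3n2)c1` gives 60000 nM in this assay.

Among these three numbers compound 1 stands second highest. Its nearest neighbour is compound 2, reached by a 2.5-fold lower number from compound 1 to compound 2 (0.40 log units; beyond the scatter), a change made at the nitrogen on the aromatic ring. Compound 3 differs from compound 1 in more than one place, and its value simply stands well above that of compound 1.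

Compound 4 `Cc1ccc(-c2nn3cc(-c4cccc(N)c4)nc3s2)cc1` is the next compound to be examined. It differs from compound 1 by hydrogen in place of methyl on a saturated chain carbon bound to an aromatic carbon; cut one bond further out, the same difference reads ethyl to methyl. Among the measured compounds shown here, no measured step touches this chain: the only single-place step available, from compound 1 to compound 2, sits elsewhere on the molecule. With nothing to suggest otherwise, a step no larger than the scatter is expected in this assay. Compound 4 is therefore estimated at 9000 nM, within 4000 nM to 20000 nM. That expectation amounts to a 1.1-fold higher number from compound 1 to compound 4 (0.05 log units; within the scatter).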

Compound 4, half-maximal inhibitory concentration: 8900 nM
Compound 4: middle estimate off by 1.0-fold (0.00 log units), on the high side, and the stated range covers the measured number.
By their numbers in this assay, from the lowest: compound 2; then compounds 1 and 4 (each within the scatter of the next); then compound 3.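

Trimming ethyl to methyl gives a 1.1-fold higher number from compound 1 to compound 4 (0.04 log units; within the scatter) in this assay, the first reading at this chain, and the two compounds cannot be told apart there. Among the compounds shown here, the only earlier single-place step, at the nitrogen on the aromatic ring, gave a 2.5-fold lower number from compound 1 to compound 2 (0.40 log units; beyond the scatter) and so left open whether any change on this molecule would stay inside the scatter; this one change at the saturated chain carbon does. No measurement in hand offers an explanation for this result.

As far as these compounds go, whether a longer chain such as propyl, or an amine or a carboxylic acid on this chain, would read the same remains open. So does whether the ethyl to methyl change would read alike with (1-bromoethenyl)carbonyl on the nitrogen, as in compound 2.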